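Benzyl variation on the triazole dithiocarbamate series

The source may hold more compounds than are shown below. What is called first, only, known or untested is meant among the compounds shown, and "the series" means these compounds.

Measured so far, in a functional assay on MGC-803 cells (Homo sapiens) for inhibition, read by MTT assay, with a stated time of 72 h; on this read-out lower numbers stand for stronger inhibition and higher numbers for weaker inhibition:
compound 1 `CC(C)(C)OC(=O)N1CCN(C(=S)SCc2cn(-c3ccccc3F)nn2)CC1` gives 119000 nM
compound 2 `Cc1ccc(Cn2cc(CSC(=S)N3CCN(C(=O)OC(C)(C)C)CC3)nn2)cc1` gives 3490 nM
compound 3 `CC(C)(C)OC(=O)N1CCN(C(=S)SCc2cn(Cc3ccc(Cl)c(Cl)c3)nn2)CC1` gives 33700 nM

Compound 3 stands second highest of the three numbers: a 3.5-fold lower number from compound 1 to compound 3 (0.55 log units; beyond the scatter), while a 9.7-fold higher number from compound 2 to compound 3 (0.98 log units; beyond the scatter). Compound 4 `CC(C)(C)OC(=O)N1CCN(C(=S)SCc2cn(Cc3ccccc3Cl)nn2)CC1` differs from compound 3 in one place: 2-chlorophenyl in place of 3,4-dichlorophenyl on a saturated chain carbon bound to an aromatic nitrogen.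

Among the measured compounds shown here, the one step at the same place is a 9.7-fold higher number from compound 2 to compound 3 (0.98 log units; beyond the scatter); the step of a 34-fold lower number from compound 1 to compound 2 (1.53 log units; beyond the scatter) changes the group on the aromatic nitrogen itself. Both point toward lower numbers when the group carries a single substituent, so a modest drop is expected for compound 4. The estimate for compound 4 is 12000 nM, range 3000 nM to 50000 nM, meaning an expected step of a 2.8-fold lower number from compound 3 to compound 4 (0.45 log units; beyond the scatter).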

Compound 4, half-maximal inhibitory concentration: 490 nM
Beside the measured number, compound 4's estimate is 24-fold (1.39 log units) above it, outside the stated range (below it).
By their numbers in this assay, from the lowest: compound 4; then compound 2; then compound 3; then compound 1.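

In this assay, among the compounds shown here, 2-chlorophenyl at this place gives the lowest number so far, with a 69-fold lower number from compound 3 to compound 4 (1.84 log units; beyond the scatter) and a 7.1-fold lower number from compound 2 to compound 4 (0.85 log units; beyond the scatter). The two chlorine-bearing benzyl groups lie on either side of 4-methylbenzyl, so the presence of chlorine alone does not set the number among these compounds. Against the 2-fluorophenyl group, 2-chlorobenzyl brings a 240-fold lower number from compound 1 to compound 4 (2.39 log units; beyond the scatter), the widest step in the set.

No supporting data bear on this result. Still open, as far as these compounds go, is how 2-fluorobenzyl, 2-methoxybenzyl or 4-chlorobenzyl would compare with 2-chlorobenzyl at this place.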